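Aryl urea series: hexyl to fluoro swap on the aryl ring

This account rests on a few compounds, and the source may have more. Where it says the series, first, only, none or still open, it means among the compounds named here.

Measured compounds in an ADME assay on the whole organism with Oryza sativa as the target, tested at 0.1 uM; on this read-out lower numbers stand for a stronger effect and higher numbers for a weaker effect at the one concentration tested:
- compound 1, `CCc1ccc(NC(=O)N[C@H](C)c2ccccc2)cc1`, gives 95%
- compound 2, `C[C@@H](NC(=O)Nc1ccc(C(C)(C)C)cc1)c1ccccc1`, gives 100%
- compound 3, `CCCCCCc1ccc(NC(=O)N[C@H](C)c2ccccc2)cc1`, gives 100%

In this assay compound 3 stands level with compound 2 at the digits printed, the two together the highest numbers of the three, with compound 1 the furthest of them, and that gap is within the scatter.

The next step goes from compound 3 to compound 4, `C[C@@H](NC(=O)Nc1ccc(F)cc1)c1ccccc1`: fluoro in place of hexyl on an aromatic carbon.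

The three measured steps all change the alkyl group on the aromatic carbon: a number 5 percentage points higher from compound 1 to compound 2 (within the scatter), a number 5 percentage points higher from compound 1 to compound 3 (within the scatter), no change at the digits printed from compound 2 to compound 3 (within the scatter). None of them moves the read-out beyond the scatter, and none exchanges the alkyl group for a fluoro, so they bear on the new step only by showing that the size of the group on that carbon has not mattered so far. The expected change is therefore small, a number 5 percentage points lower from compound 3 to compound 4 (within the scatter), with the read-out staying high. Compound 4 is expected to give about 95% in this assay. The estimate for compound 4 ranges from 78% to 100%.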

Compound 4, a percentage reported as activity, at one concentration (the size of the read-out at that concentration, not a potency): 98%
Compound 4: the middle estimate sits 3 percentage points below what was measured, within the range that was stated.
By their numbers in this assay, from the lowest: compounds 1, 4, 2 and 3 (each within the scatter of the next).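

In this assay, among the compounds shown here, fluoro is the first group at this position that is not an alkyl group, and it reads like the alkyl groups on the same aromatic carbon, para to a large group (a number 2 percentage points lower from compound 3 to compound 4 (within the scatter)) (a number 2 percentage points lower from compound 2 to compound 4 (within the scatter)) (a number 3 percentage points higher from compound 1 to compound 4 (within the scatter)). For the compounds shown here, all of these steps lie within the scatter, so at this one concentration the read-out does not separate a single fluorine atom from the 6 heavy atoms of hexyl, whereas the earlier compounds covered alkyl groups alone. No measured information accounts for this sameness across the four compounds.

From the compounds shown here alone, whether an amine or a carboxylic acid on this aromatic carbon would move the read-out beyond the scatter remains open. Also open, going by these compounds, is whether a change elsewhere on the shared core, such as replacing the urea carbonyl or the phenyl ring, would separate these compounds.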